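Quinoline series: chloro versus aminopropyl substituent in RKO cytotoxicity

A few compounds are considered here, and "the series" means these few. Any claim that something is new, unique, unknown or untested is made for them only; others in the source may bear on it.

Measured compounds:
compound 1, `Clc1ccnc2cc(OCc3ccccc3)ccc12`: 2410 nM
compound 2, `CN(C)CCCNc1ccnc2cc(OCc3ccc(F)cc3)ccc12`: 1230 nM

Both compounds were run in a functional assay on RKO cells (Homo sapiens) for cytotoxicity, read by MTT assay, with a stated time of 48 h; on this read-out lower numbers stand for stronger inhibition and higher numbers for weaker inhibition. Compound 2 has the lower of the two numbers; the nearest is compound 1, and the gap between them is within the usual scatter, so no order between the two is claimed.

Compound 3, `Fc1ccc(COc2ccc3c(Cl)ccnc3c2)cc1`, is not yet measured. It differs from compound 2 in one place: chloro in place of (3-(dimethylamino)propyl)amino on an aromatic carbon. Within the data shown here, no pair of measured compounds differs in a single place, so no measured step guides this change directly. What can be said is that compound 1, which also carries chloro rather than (3-(dimethylamino)propyl)amino, gives 2410 nM, a number close to that of compound 2.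

On this basis the step is expected to be small, towards a somewhat higher number, and possibly not beyond the scatter: the estimate for compound 3 is 2300 nM, with a range of 900 nM to 6000 nM. This estimate corresponds to an expected step of a 1.9-fold higher number from compound 2 to compound 3 (0.27 log units; within the scatter).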

Compound 3, half-maximal inhibitory concentration: 1980 nM
Estimate against measurement, compound 3: 1.2-fold (0.07 log units) above; low and high end bracket the measured number.
By their numbers in this assay, from the lowest: compounds 2, 3 and 1 (each within the scatter of the next).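

Read in this assay, this is the first matched comparison at the aromatic carbon opposite the ring nitrogen: chloro in place of (3-(dimethylamino)propyl)amino gives a 1.6-fold higher number from compound 2 to compound 3 (0.21 log units; within the scatter) and so leaves the two compounds indistinguishable, although a whole amine-bearing chain is exchanged for a single atom. The series also gains its first reading of the fluoro group, where fluoro in place of hydrogen on an aromatic carbon gives a 1.2-fold lower number from compound 1 to compound 3 (0.09 log units; within the scatter) and likewise separates nothing on this read-out. No accompanying measurement bears on why neither exchange registers beyond the scatter.

The compounds shown leave open whether this insensitivity holds for other groups at the same carbon, such as a plain amino group, a piperidine or a longer dialkylaminoalkyl chain, or whether (3-(dimethylamino)propyl)amino and chloro simply happen to read alike. They also leave open how a methoxy or trifluoromethyl group in place of the fluoro would read, and whether any such change would open a gap larger than the scatter.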